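Swapping nitro for tert-butyl on the aryl substituent

The source may hold more compounds than are shown below. What is called first, only, known or untested is meant among the compounds shown, and "the series" means these compounds.

Of the compounds shown here, two sharing one core have been measured. Compound 1 `CC(C)c1ccc(N2C(=O)C=CC2OCC(F)(F)F)cc1` carries an isopropyl group on its benzene ring, and in a functional assay on K562 cells (Homo sapiens) for inhibition (on this read-out higher numbers stand for weaker inhibition and lower numbers for stronger inhibition), compound 1 gives 6620 nM. Compound 2 `O=C1C=CC(OCC(F)(F)F)N1c1ccc([N+](=O)[O-])cc1` carries a nitro group in the same position, and in this assay compound 2 gives 1530 nM. For the measured compounds named here, this places compound 2 at the lower of the two numbers, and the only step between them, a 4.3-fold lower number from compound 1 to compound 2 (0.64 log units; beyond the scatter), ran from the alkyl group to the nitro group.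

Compound 3 `CC(C)(C)c1ccc(N2C(=O)C=CC2OCC(F)(F)F)cc1` differs from compound 2 in one place: tert-butyl in place of nitro on an aromatic carbon. Going by the values given here, no step from a nitro group to a tert-butyl group has been measured, so the only guide is the reverse of the measured step, in which an alkyl group was replaced by nitro. Running that change backwards, an increase in the number in this assay is expected, of about the same size as that step, because a 4.3-fold lower number from compound 1 to compound 2 (0.64 log units; beyond the scatter) was modest but beyond the scatter.

Compound 3 is therefore expected to show a 4.2-fold higher number from compound 2 to compound 3 (0.63 log units; beyond the scatter), landing near compound 1. The estimate for compound 3 in this assay is 6500 nM, with a range from 2500 nM to 17000 nM.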

Compound 3, half-maximal inhibitory concentration: 70 nM
Compound 3: middle estimate off by 93-fold (1.97 log units), on the high side; the whole stated range lies above it.
By their numbers in this assay, from the lowest: compound 3; then compound 2; then compound 1.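

The result shows that this aromatic carbon is far more sensitive than the first pair suggested, and that the two alkyl groups cannot be treated as one kind of substituent: tert-butyl in place of nitro gives a 22-fold lower number from compound 2 to compound 3 (1.34 log units; beyond the scatter), whereas isopropyl in place of nitro had moved the number the other way. The sharpest contrast is between the two alkyl compounds, where one added methyl on the carbon bound to the ring gives a 95-fold lower number from compound 1 to compound 3 (1.98 log units; beyond the scatter), a larger change than either step involving nitro, so that compound 2, with its nitro group, falls between them in this assay. Nothing available explains why this single methyl carries so much weight.

The compounds shown leave open how an ethyl group, a cyclopropyl ring or a trimethylsilyl group on the same aromatic carbon would read, and so whether the low number belongs to tert-butyl alone or extends to other branched groups. They also leave open whether an amine or a carboxylic acid there would read nearer to nitro, and whether the tert-butyl step would hold if the trifluoroethoxy chain on the shared core gave way to a methoxy group.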